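This account rests on a few compounds, and the source may have more. Where it says the series, first, only, none or still open, it means among the compounds named here.

Compound 1 `COc1cc(C2=NCCN2)cc2cc(-c3ccc(C4=NCCN4)cc3)oc12` gives 19900 nM in an ADME assay on L6 cells (Rattus norvegicus) for cytotoxicity; a higher number here means a weaker inhibitor, a lower number a stronger inhibitor.
Compound 2 `Oc1cc(C2=NCCN2)cc2cc(-c3ccc(C4=NCCN4)cc3)oc12` reaches only a limit of this assay, > 203000 nM.
Compound 3 `COc1cc(C(=N)NC(C)C)ccc1-c1cc2cc(C(=N)NC(C)C)ccc2o1` gives 98100 nM in this assay.

The change from compound 1 to compound 2 is hydrogen in place of methyl on an oxygen on an aromatic ring. It produced an at least 10-fold higher number from compound 1 to compound 2 (1.00 log units; beyond the scatter). The value of compound 2 is a limit, (the limit of > 203000 nM in this assay, at which 1 of the 3 values shown sits), and no number beyond it is known. Compound 3 differs from compound 1 in more than one place; the difference between the two cores is not broken down here. In this assay compound 3 gives a higher number than compound 1.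

Compound 4 `CC(C)NC(=N)c1ccc(-c2cc3cc(C(=N)NC(C)C)ccc3o2)c(O)c1` has not yet been measured. It differs from compound 3 by hydrogen in place of methyl on an oxygen on an aromatic ring, the same change as that from compound 1 to compound 2, at the same kind of place. Compound 4 is therefore expected to sit at 500000 nM, most likely between 150000 nM and 2000000 nM. This expectation means a step of a 5.1-fold higher number from compound 3 to compound 4 (0.71 log units; beyond the scatter), and it rests on the earlier step, because an at least 10-fold higher number from compound 1 to compound 2 (1.00 log units; beyond the scatter) was seen for the same change. Since compound 3 already gives a high number, compound 4 is expected to land at or beyond the limit of this assay.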

Compound 4, half-maximal inhibitory concentration: > 183000 nM
Compound 4: a limit, no number; the forecaster's own chance of this, stated with the estimate: 70%; the middle value lies beyond the limit too.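

In this assay, going from methoxy to hydroxy on the second core gives an at least 1.8-fold higher number from compound 3 to compound 4 (0.27 log units; that floor lies within the scatter), and on its own this floor does not clear the usual scatter. Compound 4 reaches only a limit of the assay, > 183000 nM, not a number. The result therefore fits the direction seen on the core of compound 1 but does not prove that the change carries over from one core to the other, and its size cannot be compared between the two cores: the same change on two cores in this assay, an at least 10-fold higher number (1.00 log units; beyond the scatter) from compound 1 to compound 2 and an at least 1.8-fold higher number (0.27 log units; that floor lies within the scatter) from compound 3 to compound 4; the limit leaves it open whether they differ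

The compounds shown leave open what happens when the oxygen on the aromatic ring carries a longer chain such as ethyl, or when an amine or a fluorine stands in place of the hydroxy group. They also leave open how large the step from methoxy to hydroxy really is on either core, since both hydroxy compounds give only limits.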